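Swapping the amide substituent from compound 1 toward compound 2

This account rests on a few compounds, and the source may have more. Where it says the series, first, only, none or still open, it means among the compounds named here.

Compound 1 `CCN(C(=O)c1cc([N+](=O)[O-])ccc1Oc1ccc(OC)cc1)c1ccc(Cl)cc1` gives 8300 nM in a functional assay (Homo sapiens) for inhibition, using a membrane potential dye, in the presence of a further agent that is not named here; on this read-out higher numbers stand for weaker inhibition and lower numbers for stronger inhibition. Among three measured compounds it has the second highest number; compound 3 `COc1ccc(Oc2ccc([N+](=O)[O-])cc2C(=O)Nc2cccc(S(N)(=O)=O)c2)cc1` gives 9900 nM, close to it, while compound 2 `COc1ccc(Oc2ccc([N+](=O)[O-])cc2C(=O)Nc2ccc(S(N)(=O)=O)cc2)cc1` gives 1800 nM, a clearly lower number. Among the compounds with values here, the one measured step, a 5.5-fold higher number from compound 2 to compound 3 (0.74 log units; beyond the scatter), shows that moving the sulfamoyl group on the amide-type nitrogen matters. Compound 4 `COc1ccc(Oc2ccc([N+](=O)[O-])cc2C(=O)Nc2ccc(C(C)=O)cc2)cc1` is not yet measured; its change from compound 1 is (4-acetylphenyl)amino in place of (4-chlorophenyl)(ethyl)amino on a carbonyl carbon. Compound 4 shares with compound 2 an unsubstituted amide nitrogen carrying a 4-substituted phenyl, so compound 4 is expected to land near compound 2, an expected step of a 3.3-fold lower number from compound 1 to compound 4 (0.52 log units; beyond the scatter). The estimate for compound 4 is 2500 nM, within 800 nM to 8000 nM.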

Compound 4, half-maximal inhibitory concentration: 8100 nM
For compound 4 the middle estimate is 3.2-fold (0.51 log units) below the measured one, outside the stated range (above it).
By their numbers in this assay, from the lowest: compound 2; then compounds 4, 1 and 3 (each within the scatter of the next).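

In this assay, replacing the whole amide substituent of compound 1 leaves the number unchanged (a 1.0-fold lower number from compound 1 to compound 4 (0.01 log units; within the scatter)), and the same holds against the 3-sulfamoylphenyl amide (a 1.2-fold lower number from compound 3 to compound 4 (0.09 log units; within the scatter)), so an amide hydrogen with a 4-substituted phenyl does not by itself match compound 2. The group on the aromatic carbon counts, as acetyl cannot stand in for sulfamoyl there (a 4.5-fold higher number from compound 2 to compound 4 (0.65 log units; beyond the scatter)). Nothing measured here explains this. As far as these compounds go, whether an amine or a carboxylic acid at that place would match sulfamoyl stays open. So does the separate contribution of the ethyl and the chlorine in compound 1.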